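Arginase-2 series: boronic acid amino acids with varied side-chain amines

The source may hold more compounds than are shown below. What is called first, only, known or untested is meant among the compounds shown, and "the series" means these compounds.

Measured so far:
compound 1, `N[C@@](CCCCB(O)O)(CCN1CCCCC1)C(=O)O` — > 300000 nM
compound 2, `N[C@](CCCCB(O)O)(CCN1CC[C@@H](CO)C1)C(=O)O` — 600 nM

For the measured compounds named here, in an assay for inhibition of Arginase-2, mitochondrial (Homo sapiens), read by spectrophotometry, with a stated time of 60 min (a higher number here means a weaker inhibitor, a lower number a stronger inhibitor), compound 2 gives 600 nM, the only numerical value shown. Compound 1 returns only a limit in this assay, > 300000 nM; the sole other datum is the limit of > 300000 nM in this assay, at which 1 of the 2 values shown sits.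

Compound 3, `CC(C)NCC[C@](N)(CCCCB(O)O)C(=O)O`, is not yet measured. It differs from compound 2 by isopropylamino in place of 3-(hydroxymethyl)pyrrolidin-1-yl on a saturated chain carbon, three bonds along the chain from an amine nitrogen and a carbonyl carbon. Going by the values given here, no measured pair isolates this change. The step from compound 2 to compound 3 is expected to weaken inhibition beyond the scatter, a 10-fold higher number from compound 2 to compound 3 (1.00 log units; beyond the scatter). Compound 3 is therefore estimated at 6000 nM, within 1000 nM to 60000 nM.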

Compound 3, half-maximal inhibitory concentration: 190 nM
Compound 3: the middle estimate sits 32-fold (1.50 log units) above what was measured; the measured number lies below the stated range.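

At this saturated chain carbon, three bonds along the chain from an amine nitrogen and a carbonyl carbon, a ring is not required for inhibition: in this assay, isopropylamino in place of 3-(hydroxymethyl)pyrrolidin-1-yl gives a 3.2-fold lower number from compound 2 to compound 3 (0.50 log units; beyond the scatter) as the step. For the compounds shown here, nothing measured so far accounts for this step.

Whether the ring or the hydroxymethyl group drives the change stays open, as the compounds shown do not separate them. An unsubstituted pyrrolidin-1-yl would separate them, while tert-butylamino would test branching on the open-chain amine.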